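Coumarin ketones: ring size of the basic amine

The source may report more compounds than this note shows. Statements on the series, on what has been measured and on what is new or still open speak of the compounds shown alone.

Measured compounds in an assay on cells for inhibition of Amine oxidase [flavin-containing] A (Homo sapiens), read by fluorescence, spectrophotometry and Amplex Red, with stated times of 60 min and 30 min; on this read-out lower numbers stand for stronger inhibition and higher numbers for weaker inhibition:
compound 1 `COc1ccc2cc(C(=O)CCN3CCCCC3)c(=O)oc2c1` gives 12200 nM
compound 2 `COc1ccc2cc(C(=O)CCN3CCCC3)c(=O)oc2c1` gives 53100 nM
compound 3 `Cc1cc(O)cc2oc(=O)c(C(=O)CCN3CCCCC3)cc12` gives 136000 nM

Compound 1 and compound 2 share a core and differ only at the amine: pyrrolidin-1-yl in place of piperidin-1-yl on a saturated chain carbon, two bonds along the chain from a carbonyl carbon. The step is a 4.4-fold higher number from compound 1 to compound 2 (0.64 log units; beyond the scatter).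

Compound 3 carries a different core from compound 1, built from the same atoms joined differently; the difference between the two cores is not broken down here. In this assay compound 3 gives the highest of the three numbers, with compound 2 the nearest and compound 1 the furthest from it, both gaps beyond the scatter.

Compound 4 `Cc1cc(O)cc2oc(=O)c(C(=O)CCN3CCCC3)cc12` is not yet measured. It stands to compound 3 as compound 2 stands to compound 1: pyrrolidin-1-yl in place of piperidin-1-yl on a saturated chain carbon, two bonds along the chain from a carbonyl carbon. The two place descriptions are identical word for word, so this is the same change made on the other core, and it appears twice across the four compounds.

Among the measured compounds shown here, the only precedent for this change is the single step on the core of compound 1. For the measured compounds named here, with no second example, the expectation for compound 4 rests on carrying that step over to compound 3 unaltered. For compound 4 the step expected is a 3.7-fold higher number from compound 3 to compound 4 (0.57 log units; beyond the scatter), because the measured step was a 4.4-fold higher number from compound 1 to compound 2 (0.64 log units; beyond the scatter) and compound 3 already starts from 136000 nM. Compound 4 is accordingly estimated at 500000 nM, with a range from 200000 nM to 1500000 nM; a number this weak may well be reported only as a limit of the assay.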

Compound 4, half-maximal inhibitory concentration: 173000 nM
Compound 4: middle estimate off by 2.9-fold (0.46 log units), on the high side, and the stated range ends above it.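

In this assay, the exchange of piperidin-1-yl for pyrrolidin-1-yl on the core of compound 3 gives a 1.3-fold higher number from compound 3 to compound 4 (0.10 log units; within the scatter), so on this core the ring size of the amine makes no difference that can be read, unlike the clear step on the core of compound 1. The exchange therefore does not travel between the two cores as a fixed step, and a step measured on one core is a poor guide to the other: the same change on two cores in this assay, a 4.4-fold higher number (0.64 log units; beyond the scatter) from compound 1 to compound 2 and a 1.3-fold higher number (0.10 log units; within the scatter) from compound 3 to compound 4, 3.4-fold (0.53 log units) apart, beyond the scatter of two such steps. This does not show what in the cores sets the two steps apart, since the cores differ as wholes and each contributes a single pair, nor does it show how the exchange would behave on any further core.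

Open, on these data alone, is whether other amines, such as morpholin-4-yl, azepan-1-yl or an open-chain diethylamino group, would separate on the core of compound 3 or would again fall close together there, and how far they would spread on the core of compound 1. Also open, as far as these compounds go, is whether a longer chain between the carbonyl and the amine would leave the difference between the two cores in place.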